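Methoxy on the benzyl arm of compound 3

The source may report more compounds than this note shows. Statements on the series, on what has been measured and on what is new or still open speak of the compounds shown alone.

Compound 3 `O=C(NO)c1ccc(CN2C(=O)NC(Cc3ccccc3)(c3ccccc3)C2=O)cc1` gives 71.9 nM in an assay on isolated protein for inhibition of protein deacetylase HDAC6 (Homo sapiens), read by fluorescence, with stated times of 10 min and 2 h (a higher number here means a weaker inhibitor, a lower number a stronger inhibitor), the highest of the three numbers in hand. Compound 1 `O=C(NO)c1ccc(CN2C(=O)CN(Cc3ccccc3)C2=O)cc1` gives 12.5 nM and compound 2 `Cc1ccc(CN2CC(=O)N(Cc3ccc(C(=O)NO)cc3)C2=O)cc1` gives 17.6 nM, both of them beyond the scatter from compound 3. Compound 4 `COc1ccc(CC2(c3ccccc3)NC(=O)N(Cc3ccc(C(=O)NO)cc3)C2=O)cc1` differs from compound 3 in one place: methoxy in place of hydrogen on an aromatic carbon, read one bond further out as benzyl to 4-methoxybenzyl. For the measured compounds named here, the one measured step that bears on a small group entering an aromatic carbon of this kind is a 1.4-fold higher number from compound 1 to compound 2 (0.15 log units; within the scatter), and that step lies within the scatter. Going by the values given here, no methoxy step is known, so the methyl step is the nearest guide, and it argues against any sizeable movement. On that basis the step of a 1.0-fold lower number from compound 3 to compound 4 (0.01 log units; within the scatter) is expected to stay within the scatter, with no clear direction. Compound 4 is therefore estimated at 70 nM, with a range from 30 nM to 170 nM.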

Compound 4, half-maximal inhibitory concentration: 72.4 nM
Compound 4: the middle estimate sits 1.0-fold (0.01 log units) below what was measured, and the stated range covers the measured number.
By their numbers in this assay, from the lowest: compounds 1 and 2 (each within the scatter of the next); then compounds 3 and 4 (each within the scatter of the next).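

In this assay, methoxy in place of hydrogen on an aromatic carbon, para to a large group, gives a 1.0-fold higher number from compound 3 to compound 4 (0.00 log units; within the scatter). For the compounds shown here, this is the first step read on the benzyl arm of compound 3, and it shows that benzyl to 4-methoxybenzyl leaves the number within the scatter on this core. Beside it, a 1.4-fold higher number from compound 1 to compound 2 (0.15 log units; within the scatter) is a methyl step on a different core, so the two compounds pairs give two small groups on aromatic carbons with neither step beyond the scatter, and no compound here goes against that. Nothing in hand accounts for the size of this step.

As far as these compounds go, whether an amine or a carboxylic acid at the same place would also stay within the scatter remains open. So does the reading of a longer chain, such as butoxy, in place of the methoxy.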